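Changing the chain end of a stable series

The source may report more compounds than this note shows. Statements on the series, on what has been measured and on what is new or still open speak of the compounds shown alone.

- compound 1 `CN(C)CCCCN(C[C@H]1Cc2ncccc2CN1)[C@H]1CCCc2cccnc21`: 100%
- compound 2 `c1cnc2c(c1)CN[C@@H](CN(CCCCNC1CCOCC1)[C@H]1CCCc3cccnc31)C2`: 97%
- compound 3 `CN(CCCCN(C[C@H]1Cc2ncccc2CN1)[C@H]1CCCc2cccnc21)C1CCOCC1`: 100%

These values come from an ADME assay on microsomes from liver (Homo sapiens) for metabolic stability, using NADPH, with a stated time of 10 min; on this read-out higher numbers stand for a more stable compound and lower numbers for a less stable compound. Compound 3 stands level with compound 1, and compound 2 sits within the scatter of both. The next structure, compound 4 `c1cnc2c(c1)CN[C@@H](CN(CCCC1CCNCC1)[C@H]1CCCc3cccnc31)C2`, alters the end of the chain: piperidin-4-yl in place of (methyl(oxan-4-yl)amino)methyl on a saturated chain carbon, three bonds along the chain from an amine nitrogen. Three measured steps changed this chain end: a number 3 percentage points lower from compound 1 to compound 2 (within the scatter), no change at the digits printed from compound 1 to compound 3 (within the scatter) and a number 3 percentage points higher from compound 2 to compound 3 (within the scatter). All three stayed within the scatter, but none of them brings in piperidin-4-yl, so they offer only a loose guide. No step beyond the scatter is therefore expected, though a small fall remains possible. The estimated change is a number 6 percentage points lower from compound 3 to compound 4 (within the scatter). For compound 4, the expected value is 94%, with an estimated range from 80% to 100%.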

Compound 4, percent of the compound remaining: 100%
Beside the measured number, compound 4's estimate is 6 percentage points below it, and the stated range covers the measured number.
By their numbers in this assay, from the lowest: compounds 2, 1, 3 and 4 (each within the scatter of the next).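

Piperidin-4-yl on this saturated chain carbon fits as well as the earlier chain ends in this assay, with no change at the digits printed from compound 3 to compound 4 (within the scatter) and a number 3 percentage points higher from compound 2 to compound 4 (within the scatter) and also no change at the digits printed from compound 1 to compound 4 (within the scatter) in this series. Across these four compounds, the chain-end nitrogen can therefore sit inside a ring with no shift beyond the scatter. No supporting measurement explains this result.

All four numbers lie so close together that they give little sign of what this position will not accept. Going by these compounds, whether a carboxylic acid or a longer chain here would lower the number remains open.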